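This account rests on a few compounds, and the source may have more. Where it says the series, first, only, none or still open, it means among the compounds named here.

Three members of this series have a number in a functional assay on BE(2)-C cells (Homo sapiens) for inhibition, read by MTT assay, with a stated time of 72 h; a lower number here means a stronger inhibitor of growth, a higher number a weaker inhibitor of growth. Compound 1 `O=S(=O)(NCCNCc1ccc(-c2ccccc2)cc1)c1cc(C(F)(F)F)cc(C(F)(F)F)c1` gives 2700 nM, compound 2 `O=S(=O)(NCCCNCc1ccc(C(F)(F)F)cc1)c1cc(C(F)(F)F)cc(C(F)(F)F)c1` gives 2700 nM, and compound 3 `O=S(=O)(NCCNCc1cccc2ccccc12)c1cc(C(F)(F)F)cc(C(F)(F)F)c1` gives 19000 nM. Compound 2 and compound 1 stand level with each other at the digits shown, and together they sit at the low end of the three numbers; compound 3 lies well above them, beyond the usual scatter.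

Compound 4 `COc1ccc(CNCCCNS(=O)(=O)c2cc(C(F)(F)F)cc(C(F)(F)F)c2)cc1` has not yet been measured in this assay. It departs from compound 2 in one place: methoxy in place of trifluoromethyl on an aromatic carbon. Among the compounds with values here, no measured pair carries this particular change, so its effect cannot be read off directly.

Given that compound 1 and compound 2 give the same number in this assay with differently sized groups at the outer ring, the expectation is that compound 4 stays close to compound 2, with at most a small step of a 1.3-fold higher number from compound 2 to compound 4 (0.11 log units; within the scatter) that may not exceed the scatter. Compound 4 is estimated at 3500 nM in this assay, within a range of 1200 nM to 10000 nM.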

Compound 4, concentration for 50% growth inhibition: 2800 nM
Beside the measured number, compound 4's estimate is 1.3-fold (0.10 log units) above it; measured number inside the range.
By their numbers in this assay, from the lowest: compounds 1, 2 and 4 (each within the scatter of the next); then compound 3.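

In this assay, methoxy in place of trifluoromethyl on the aromatic carbon para to a large group gives a 1.0-fold higher number from compound 2 to compound 4 (0.02 log units; within the scatter). Within the data shown here, this is the first direct reading at this position: the change swaps a group of three fluorine atoms and one carbon for one carrying a hydrogen-bond acceptor, with no difference beyond the scatter. No measurement shown here offers an explanation for this result.

From the compounds shown here alone, whether the position also accepts an amine, a carboxylic acid or a nitrile remains open, as does the outcome of moving methoxy elsewhere on the ring. Among the compounds shown, no pair differs in the linking chain alone, so the contribution of the chain remains unread.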